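The compounds below may be only part of what the source reports. "The series", "measured", "known", "first", "only" and "open" are said of these compounds alone.

Measured so far in a functional assay on A549 cells (Homo sapiens) for cytotoxicity, read by MTT assay, with a stated time of 72 h; a lower number here means a stronger inhibitor, a higher number a weaker inhibitor:
compound 1, `O=C(Nc1nc2ccc(F)cc2s1)c1cn(-c2ccccc2)nc1-c1ccccc1`: 10200 nM
compound 2, `Cc1ccc2nc(NC(=O)c3cn(-c4ccccc4)nc3-c3ccc(F)cc3)sc2c1`: 24600 nM
compound 3, `O=C(Nc1nc2ccc(F)cc2s1)c1cn(-c2ccccc2)nc1-c1ccc(Cl)cc1`: 8860 nM

In this assay compound 3 gives the lowest of the three numbers, but its nearest neighbour is compound 1, and the step of a 1.2-fold lower number from compound 1 to compound 3 (0.06 log units; within the scatter) lies within the scatter, so the two cannot be told apart. For the measured compounds named here, compound 2 stands furthest from compound 3, with a gap beyond the scatter; compound 2 is not a single-step neighbour of compound 3, so no measured step links them.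

Compound 4, `Cc1ccc2nc(NC(=O)c3cn(-c4ccccc4)nc3-c3ccc(Cl)cc3)sc2c1`, is not yet measured. It differs from compound 3 in one place: methyl in place of fluoro on an aromatic carbon; cut one bond further out, this reads 6-fluoro-1,3-benzothiazol-2-yl to 6-methyl-1,3-benzothiazol-2-yl. Going by the values given here, no measured single step touches this place; the only measured step, from compound 1 to compound 3, concerns the chloro on the other ring and is within the scatter. Among the compounds with values here, the only guide is compound 2, which carries the same methyl and in this assay gives 24600 nM, a higher number than compound 3. Compound 4 is therefore expected to give a somewhat higher number, a 1.8-fold higher number from compound 3 to compound 4 (0.26 log units; within the scatter), with wide uncertainty. The estimate for compound 4 is 16000 nM, between 6000 nM and 40000 nM.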

Compound 4, half-maximal inhibitory concentration: 18600 nM
Compound 4: middle estimate off by 1.2-fold (0.07 log units), on the low side; low and high end bracket the measured number.
By their numbers in this assay, from the lowest: compounds 3, 1, 4 and 2 (each within the scatter of the next, the first and the last beyond it).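

In this assay, for the compounds shown here, the change from 6-fluoro-1,3-benzothiazol-2-yl to 6-methyl-1,3-benzothiazol-2-yl gives the first measured step at this place, a 2.1-fold higher number from compound 3 to compound 4 (0.32 log units; beyond the scatter), which is modest but lies beyond the scatter, so swapping fluoro for methyl here does register in the number. The other new step, a 1.3-fold lower number from compound 2 to compound 4 (0.12 log units; within the scatter), lies within the scatter, so with methyl on the fused ring system, chloro in place of fluoro on the far aromatic ring cannot be told apart from no change, much as chloro in place of hydrogen could not be in the step of a 1.2-fold lower number from compound 1 to compound 3 (0.06 log units; within the scatter) among the compounds carrying fluoro. Nothing among the data shown explains why methyl and fluoro differ at this place.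

The comparison rests on a single pair that only just clears the scatter, so it is still unclear whether the difference would hold in a compound with another group on the far aromatic ring. As far as these compounds go, what an amine, a methoxy group or a carboxylic acid would do at this place also stays open.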